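Swapping the 4-cyanobenzyl group for 2-fluorobenzyl

The source may hold more compounds than are shown below. What is called first, only, known or untested is meant among the compounds shown, and "the series" means these compounds.

Compound 1 `N#Cc1ccc(Cn2c(/C=C3\SC(=S)N(CC(=O)O)C3=O)nc3ccccc32)cc1` carries a 4-cyanobenzyl group on the shared core. Among the compounds with values here, in a functional assay on HeLa cells (Homo sapiens) for cytotoxicity, read by MTT assay, with a stated time of 48 h (a higher number here means a weaker inhibitor, a lower number a stronger inhibitor), compound 1 gives 16300 nM, the highest of the two numbers known so far. Compound 2 `O=C(O)CN1C(=O)/C(=C/c2nc3ccccc3n2Cc2ccc(F)cc2)SC1=S` differs from it only by fluoro in place of cyano on an aromatic carbon, and in this assay compound 2 gives 13900 nM; the step of a 1.2-fold lower number from compound 1 to compound 2 (0.07 log units; within the scatter) lies within the scatter. Compound 3 `O=C(O)CN1C(=O)/C(=C/c2nc3ccccc3n2Cc2ccccc2F)SC1=S` has not yet been measured. Its difference from compound 1 is 2-fluorophenyl in place of 4-cyanophenyl on a saturated chain carbon bound to an aromatic nitrogen. Within the data shown here, the only measured step that bears on this change is a 1.2-fold lower number from compound 1 to compound 2 (0.07 log units; within the scatter), which likewise puts a fluorine in place of the cyano group on the same aromatic ring; it was small. Nothing else among the measured compounds speaks to the change. The expected step of a 1.1-fold lower number from compound 1 to compound 3 (0.04 log units; within the scatter) is therefore none beyond the scatter. Compound 3 is estimated at 15000 nM, with a range from 7000 nM to 32000 nM.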

Compound 3, half-maximal inhibitory concentration: 640 nM
For compound 3 the middle estimate is 23-fold (1.37 log units) above the measured one; the whole stated range lies above it.
By their numbers in this assay, from the lowest: compound 3; then compounds 2 and 1 (each within the scatter of the next).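

In this assay the group on a saturated chain carbon bound to an aromatic nitrogen proves far from indifferent: the earlier pair showed no step beyond the scatter, yet 4-cyanobenzyl to 2-fluorobenzyl gives a 25-fold lower number from compound 1 to compound 3 (1.41 log units; beyond the scatter) on the shared core. With fluorine on the ring in both compounds, 2-fluorophenyl in place of 4-fluorophenyl gives a 22-fold lower number from compound 2 to compound 3 (1.34 log units; beyond the scatter) and so shows that, in this series, where the fluorine sits matters and its presence alone does not decide the outcome. No evidence on the origin of these steps is at hand.

Whether the large step is specific to fluorine stays open, as no compound shown has a chlorine or a methoxy group in place of the fluorine of the 2-fluorobenzyl group. Also open, from the compounds shown here alone, is whether the step persists with an amide in place of the carboxylic acid.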